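The source may report more compounds than this note shows. Statements on the series, on what has been measured and on what is new or still open speak of the compounds shown alone.

In an ADME assay on HEp-2 cells (Homo sapiens) for cytotoxicity, read by CCK-8 assay, with a stated time of 5 days (on this read-out higher numbers stand for lower toxicity in this test and lower numbers for higher toxicity in this test), three compounds have been measured:

compound 1 `NC(=O)NCCNc1cc(N2CCc3ccccc3C2)nc2ccccc12`, 80000 nM;
compound 2 `Cc1ccc2nc(N3CCCc4ccccc4C3)cc(NCCN)c2c1`, 9400 nM;
compound 3 `Cc1ccc2nc(N3CCCc4ccc(F)cc4C3)cc(NCCN)c2c1`, > 3200 nM.

The value of compound 3 is a limit of the test and not a number, namely (the limit of > 3200 nM in this assay, at which 1 of the 3 values shown sits). Compound 4 `Cc1ccc2nc(N3CCCc4ccc(F)cc4C3)cc(NC(C)CN)c2c1` differs from compound 3 by methyl in place of hydrogen on a saturated chain carbon bound to a nitrogen on an aromatic ring and a saturated chain carbon. Within the data shown here, only one single change has been measured: the step from compound 2 to compound 3 reads a step that the limit leaves unreadable from compound 2 to compound 3, and no measured step touches the chain that carries the new methyl. The size of the step in this assay therefore cannot be read from these data, and no step beyond the scatter is assumed. Compound 4 is expected near 8000 nM, with a range from 2500 nM to 30000 nM, the expected step from compound 3 being a step that the limit leaves unreadable from compound 3 to compound 4.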

Compound 4, half-maximal cytotoxic concentration: 25000 nM
Compound 4: middle estimate off by 3.1-fold (0.49 log units), on the low side; the measured number falls inside the stated range.
By their numbers in this assay, from the lowest: compound 2; then compound 4; then compound 1.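

The step from compound 3 to compound 4 cannot be read, because the value of compound 3 is a limit and not a number: the limit of > 3200 nM in this assay, at which 1 of the 4 values shown sits. The compounds shown leave open what size of step the methyl brings on this chain.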